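Aromatic ring returns to the carbonyl carbon of compound 3

The source may hold more compounds than are shown below. What is called first, only, known or untested is meant among the compounds shown, and "the series" means these compounds.

Three compounds of this series share one core and differ only in the group on a carbonyl carbon whose other neighbour is a double-bonded chain carbon. In a functional assay on A-375 cells (Homo sapiens) for cytotoxicity, read by MTT assay, with a stated time of 48 h (a higher number here means a weaker inhibitor, a lower number a stronger inhibitor), compound 1 `CC1(C)S[C@@H]2/C(=C\C(=O)c3ccc4ccccc4c3)C(=O)N2[C@H]1C(=O)OC(c1ccccc1)c1ccccc1` gives 36500 nM, compound 2 `CC1(C)S[C@@H]2/C(=C\C(=O)c3ccco3)C(=O)N2[C@H]1C(=O)OC(c1ccccc1)c1ccccc1` gives 26000 nM, and compound 3 `CC1(C)S[C@@H]2/C(=C\C(=O)OCc3ccccc3)C(=O)N2[C@H]1C(=O)OC(c1ccccc1)c1ccccc1` gives 7100 nM. Compound 3 stands lowest of the three: the step of a 3.7-fold lower number from compound 2 to compound 3 (0.56 log units; beyond the scatter) and the step of a 5.1-fold lower number from compound 1 to compound 3 (0.71 log units; beyond the scatter) both lie beyond the scatter, while a 1.4-fold lower number from compound 1 to compound 2 (0.15 log units; within the scatter) does not.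

Compound 4 `CC1(C)S[C@@H]2/C(=C\C(=O)c3cc(F)cc(F)c3)C(=O)N2[C@H]1C(=O)OC(c1ccccc1)c1ccccc1` is not yet measured. Its difference from compound 3 is 3,5-difluorophenyl in place of benzyloxy on a carbonyl carbon. Among the measured compounds shown here, the steps that bear on it are the two that already connect a ring on this carbonyl carbon with the benzyloxy group: a 5.1-fold lower number from compound 1 to compound 3 (0.71 log units; beyond the scatter) and a 3.7-fold lower number from compound 2 to compound 3 (0.56 log units; beyond the scatter). Both ran toward a lower number when benzyloxy entered; compound 4 reverses that, so a step back toward a higher number is expected in this assay, of roughly the size seen for compound 1 and compound 2. The expected step is a 3.5-fold higher number from compound 3 to compound 4 (0.55 log units; beyond the scatter). Compound 4 is therefore estimated at 25000 nM, with a range from 8000 nM to 70000 nM. For the measured compounds named here, the 3,5-difluorophenyl group itself has no measured counterpart here, so the range is kept wide.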

Compound 4, half-maximal inhibitory concentration: 19100 nM
Compound 4: middle estimate off by 1.3-fold (0.12 log units), on the high side, within the range that was stated.
By their numbers in this assay, from the lowest: compound 3; then compounds 4, 2 and 1 (each within the scatter of the next).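

In this assay, a 2.7-fold higher number from compound 3 to compound 4 (0.43 log units; beyond the scatter), so the lower number of compound 3 does not carry over to a group with the same heavy-atom count and one six-membered aromatic ring of carbon only, once that ring sits directly on the carbonyl carbon and the oxygen of benzyloxy is gone. The other comparisons, a 1.4-fold lower number from compound 2 to compound 4 (0.13 log units; within the scatter) and a 1.9-fold lower number from compound 1 to compound 4 (0.28 log units; within the scatter), both lie within the scatter, so furan-2-yl, naphthalen-2-yl and 3,5-difluorophenyl cannot be told apart here, and among these four compounds only benzyloxy stands apart, with no exception among the compounds shown. No measurement here accounts for this separation.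

Still open, going by these compounds, is whether the separation belongs to the oxygen link or to the benzyl group as a whole: an ethoxy group on this carbonyl carbon, or a benzylamino group with nitrogen in place of that oxygen, would pull these two apart. Also open, on these data alone, is whether the two fluorines count for anything, which a plain phenyl on the same carbonyl carbon would show when set against compound 4.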